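Trading an amide for an ester on a shared core

A few compounds are considered here, and "the series" means these few. Any claim that something is new, unique, unknown or untested is made for them only; others in the source may bear on it.

The three measured compounds share one core and differ only in the aromatic ring attached to a saturated ring carbon. Compound 1 `CC1=C(C(=O)NC(C)C)C(c2ccco2)NC(=O)N1` carries a furan-2-yl group there. In an assay on membranes from HeLa cells for displacement of a labelled ligand from adenosine receptor A3 (Homo sapiens), read by scintillation counting, with a stated time of 180 min, tested at 1 uM (a lower number here means less inhibition, a higher number more inhibition at the concentration tested (going by the name of the read-out)), compound 1 gives 4%. Compound 2 `CC1=C(C(=O)NC(C)C)C(c2ccoc2)NC(=O)N1`, with furan-3-yl in place of furan-2-yl, gives 3% in this assay, a change of a number 1 percentage points lower from compound 1 to compound 2 (within the scatter). Compound 3 `CC1=C(C(=O)NC(C)C)C(c2cccs2)NC(=O)N1`, with thiophen-2-yl in place of furan-2-yl, gives 1%, a change of a number 3 percentage points lower from compound 1 to compound 3 (within the scatter); the step of a number 2 percentage points lower from compound 2 to compound 3 (within the scatter) is likewise small. Compound 1 sits at the top of these three numbers, yet both others lie within the usual scatter of it, so none of the three stands apart.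

Compound 4 `CC1=C(C(=O)OC2CCCC2)C(c2ccco2)NC(=O)N1` departs from compound 1 at a different place: cyclopentyloxy in place of isopropylamino on a carbonyl carbon. The carbonyl carbon on which this change sits is untouched by the measured steps; all three concern the aromatic ring on the saturated ring carbon, and all three were within the scatter. What they show is that the shared core, bearing the isopropylamino amide, stayed near the bottom of the read-out scale whichever aromatic ring it carried. Nothing measured here tells whether swapping that amide for an ester moves the number. The expected step is therefore a number 1 percentage points higher from compound 1 to compound 4 (within the scatter), nothing beyond the scatter. Compound 4 is estimated at 5%, within a range from 0% to 18% in this assay.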

Compound 4, a percentage reported as inhibition, at one concentration (the size of the read-out at that concentration, not a potency): 14%
Beside the measured number, compound 4's estimate is 9 percentage points below it, within the range that was stated.
By their numbers in this assay, from the lowest: compounds 3, 2, 1 and 4 (each within the scatter of the next, the first and the last beyond it).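

Within the data shown here, this is the first measured change at the carbonyl carbon rather than on the aromatic ring, and in this assay it is a number 10 percentage points higher from compound 1 to compound 4 (within the scatter), which leaves the ester and the amide indistinguishable in this read-out. The exchange is a large one on paper: the nitrogen of the isopropylamino group gives way to an oxygen, and a five-membered ring of carbon enters, yet the pair still cannot be separated by this single-concentration measurement, so compound 4 does not establish that the ester is any better than the amide. No measurement shown here offers any explanation for the number at this position.

Because the linking atom and the attached carbon group differ at once, the two compounds cannot show which of them matters, and an isopropyl ester or a cyclopentylamino amide would pull those two parts apart. Going by these compounds, it also remains open whether a carboxylic acid or a longer chain such as an n-hexyl ester at this carbonyl carbon would give a number clearly beyond the scatter, and whether furan-3-yl or thiophen-2-yl would behave on the ester as they do on the amide.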